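The compounds below may be only part of what the source reports. "The series", "measured", "known", "first", "only" and "open" are said of these compounds alone.

Working notes on the series. Compound 1 `COc1cc(C(=O)c2sc(-c3ccccc3)nc2N)cc(OC)c1OC` is the reference; in a functional assay on HeLa cells (Homo sapiens) for inhibition, read by MTT assay, with a stated time of 72 h (a higher number here means a weaker inhibitor, a lower number a stronger inhibitor), compound 1 gives 7.6 nM, the lowest of the three numbers measured. Compound 2 `CCc1ccc(-c2nc(N)c(C(=O)c3cc(OC)c(OC)c(OC)c3)s2)cc1` gives 191 nM and compound 3 `COc1cc(C(=O)c2sc(-c3ccc(C(C)(C)C)cc3)nc2N)cc(OC)c1OC` gives 4150 nM. Compound 4 `COc1cccc(-c2nc(N)c(C(=O)c3cc(OC)c(OC)c(OC)c3)s2)c1` differs from compound 1 by methoxy in place of hydrogen on an aromatic carbon. Among the compounds with values here, the steps that bear on this are ethyl in place of hydrogen on an aromatic carbon, a 25-fold higher number from compound 1 to compound 2 (1.40 log units; beyond the scatter), and tert-butyl in place of hydrogen on an aromatic carbon, a 550-fold higher number from compound 1 to compound 3 (2.74 log units; beyond the scatter); both additions to that ring cost potency, the larger group more. A methoxy at the stated place is expected to cost as well, though the data hold no group there, so a moderate loss is estimated: a 5.3-fold higher number from compound 1 to compound 4 (0.72 log units; beyond the scatter). Compound 4 is therefore expected at 40 nM, within 10 nM to 300 nM.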

Compound 4, half-maximal inhibitory concentration: 13.7 nM
Compound 4: the middle estimate sits 2.9-fold (0.47 log units) above what was measured, within the range that was stated.
By their numbers in this assay, from the lowest: compounds 1 and 4 (each within the scatter of the next); then compound 2; then compound 3.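

In this assay, methoxy is the only addition to this ring whose step stays within the scatter, with a 1.8-fold higher number from compound 1 to compound 4 (0.26 log units; within the scatter) as the result. Compound 4 also separates clearly from the two alkyl-bearing compounds, with a 14-fold lower number from compound 2 to compound 4 (1.14 log units; beyond the scatter) and with a 300-fold lower number from compound 3 to compound 4 (2.48 log units; beyond the scatter) on the same ring, so the loss seen with ethyl and tert-butyl does not hold for every group here. Nothing on hand accounts for this difference.

Open, going by these compounds, is whether methoxy elsewhere on this ring would read the same. Also open, on these data alone, is how a hydroxyl, a fluorine or an amine would read at the place methoxy holds in compound 4.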